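Swapping a Fluoro for a Chloro on the Phenyl Ring

The source may report more compounds than this note shows. Statements on the series, on what has been measured and on what is new or still open speak of the compounds shown alone.

Compound 1, `CCOC(=O)C1=C(C)NC(C)=C(C(=O)OCC)C1c1c(-c2ccc(F)cc2)nc2sccn12`: in an ADME assay on Right cardiac atrium (Cavia porcellus) (a lower number here means that less compound is needed, a higher number that more compound is needed for the effect), compound 1 gives 1650 nM
Compound 2, `CCOC(=O)C1=C(C)NC(C)=C(C(=O)OCC)C1c1c(-c2ccc(F)cc2)nc2sc(Cl)cn12`: in this assay compound 2 gives 1730 nM

Of the compounds shown here, two have been measured so far, and they sit close together. Compound 2 gives the higher of the two numbers, but the gap between the two is a 1.0-fold higher number from compound 1 to compound 2 (0.02 log units; within the scatter), so they cannot be told apart on this read-out. The change that separates them is a chloro in place of a hydrogen on an aromatic carbon of the shared core.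

Compound 3, `CCOC(=O)C1=C(C)NC(C)=C(C(=O)OCC)C1c1c(-c2ccc(Cl)cc2)nc2sc(Cl)cn12`, differs from compound 2 in one place: chloro in place of fluoro on an aromatic carbon. Within the data shown here, no measured step touches this position. Among the measured compounds shown here, the only step in hand, from compound 1 to compound 2, exchanged a hydrogen for a chloro on a different ring and gave a 1.0-fold higher number from compound 1 to compound 2 (0.02 log units; within the scatter), so it offers no reason to expect a shift in this assay in either direction. In the absence of any pointer, compound 3 is expected to land near compound 2, a step of a 1.0-fold lower number from compound 2 to compound 3 (0.01 log units; within the scatter). The estimate for compound 3 in this assay is 1700 nM, with a range from 800 nM to 3600 nM.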

Compound 3, half-maximal effective concentration: 1730 nM
Compound 3: the middle estimate sits 1.0-fold (0.01 log units) below what was measured; the range from low to high includes it.
By their numbers in this assay, from the lowest: compounds 1, 2 and 3 (each within the scatter of the next).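

Chloro in place of fluoro, read here as 4-fluorophenyl to 4-chlorophenyl, is the first change among these compounds at this spot on the six-membered aromatic ring, and in this assay it gives no change at the digits printed from compound 2 to compound 3 (within the scatter). Among these compounds, the one earlier step, a 1.0-fold higher number from compound 1 to compound 2 (0.02 log units; within the scatter), concerned a hydrogen and a chloro on a different ring, so it said nothing about this position; now it is clear that these two halogens cannot be told apart here on this read-out. Nothing measured on these compounds speaks to what lies behind this result.

Among the compounds shown here, both groups compared at this position are single halogen atoms, so the result covers only that narrow exchange and cannot be stretched to larger or different groups. Whether the same holds for a methoxy group, an amine or a carboxylic acid at this position remains open, as does the effect of a plain hydrogen there, and any of these could give a clearly different number in this assay or one that matches the three compounds shown.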